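This account rests on a few compounds, and the source may have more. Where it says the series, first, only, none or still open, it means among the compounds named here.

In a functional assay on HepG2 cells (Homo sapiens) for inhibition, read by fluorescence and resazurin assay, with a stated time of 72 h (on this read-out lower numbers stand for stronger inhibition and higher numbers for weaker inhibition), two compounds have been measured so far. Compound 1 `O=C(Nc1ccccc1)Nc1cccc(Nc2nccc(Nc3ccc4cn[nH]c4c3)n2)c1` gives 8200 nM, and compound 2 `Cc1cnc(Nc2cccc(NC(=O)Nc3ccccc3)c2)nc1Nc1ccc2cn[nH]c2c1` gives 3600 nM, the lower of the two numbers and so the stronger inhibition of this pair. The next compound, compound 3 `O=C(Nc1ccccc1)Nc1cccc(Nc2ncc(Cl)c(Nc3ccc4cn[nH]c4c3)n2)c1`, keeps the shared core but exchanges one small group: chloro in place of methyl on an aromatic carbon. Put simply, compound 3 carries chloro where compound 2 carries methyl, ortho to a (1H-indazol-6-yl)amino group. Within the data shown here, no measured compound carries chloro, so the data give no direct guide to this exchange. Among the measured compounds shown here, the only measured step at this carbon, methyl in place of hydrogen, was a 2.3-fold lower number from compound 1 to compound 2 (0.36 log units; beyond the scatter), which is a modest change. On the strength of that single step, only a small change is expected in this assay, with no firm direction and quite possibly nothing beyond the scatter. The expected step is a 1.1-fold lower number from compound 2 to compound 3 (0.05 log units; within the scatter). For compound 3 the estimated value is 3200 nM, with an expected range from 1200 nM to 8500 nM.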

Compound 3, half-maximal inhibitory concentration: 3500 nM
Beside the measured number, compound 3's estimate is 1.1-fold (0.04 log units) below it, within the range that was stated.
By their numbers in this assay, from the lowest: compounds 3 and 2 (each within the scatter of the next); then compound 1.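

In this assay the exchange at this carbon, ortho to a (1H-indazol-6-yl)amino group, comes to a 1.0-fold lower number from compound 2 to compound 3 (0.01 log units; within the scatter) and so does not separate chloro from methyl. Chloro in place of hydrogen gives a 2.3-fold lower number from compound 1 to compound 3 (0.37 log units; beyond the scatter) and methyl in place of hydrogen gave a 2.3-fold lower number from compound 1 to compound 2 (0.36 log units; beyond the scatter) as its counterpart, so among these three compounds, the one with hydrogen at this carbon stands apart from the two that carry a group there, by a modest step in each case. Nothing else at hand bears on this result, so it remains an observation without an explanation.

With only hydrogen, methyl and chloro shown on this carbon, it remains open whether an amine, a methoxy group or a longer chain would move the number further, and in which direction. On these data alone, all three numbers also come from this assay alone, so it stays unknown whether methyl and chloro would match as closely on any other read-out or on a different shared core.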